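Substituent next to the ring nitrogen: three amines and ethers, one thioether

The source may report more compounds than this note shows. Statements on the series, on what has been measured and on what is new or still open speak of the compounds shown alone.

Measured compounds in an assay on cells for antagonist activity at transient receptor potential cation channel subfamily V member 1 (Homo sapiens), read by FLIPR and calcium flux, with a stated time of 6 min; a higher number here means a weaker inhibitor, a lower number a stronger inhibitor:
compound 1 `CCCCN(C)c1nc(C(C)(C)C)ccc1CNC(=O)C(C)c1ccc(NS(C)(=O)=O)c(F)c1`: 1.2 nM
compound 2 `CC(C(=O)NCc1ccc(C(C)(C)C)nc1N1CCCCCC1)c1ccc(NS(C)(=O)=O)c(F)c1`: 0.9 nM
compound 3 `CC(C)CCOc1nc(C(C)(C)C)ccc1CNC(=O)C(C)c1ccc(NS(C)(=O)=O)c(F)c1`: 0.8 nM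

The three measured compounds share one core and differ only in the group on the aromatic carbon next to the ring nitrogen. Compound 1 has the highest number of the three, yet all three values lie within the scatter of one another: the step of a 1.3-fold lower number from compound 1 to compound 2 (0.12 log units; within the scatter) and the step of a 1.5-fold lower number from compound 1 to compound 3 (0.18 log units; within the scatter) are both within the scatter, as is a 1.1-fold lower number from compound 2 to compound 3 (0.05 log units; within the scatter). No ordering among compound 1, compound 2 and compound 3 can therefore be claimed.

Compound 4 `CCCCCSc1nc(C(C)(C)C)ccc1CNC(=O)C(C)c1ccc(NS(C)(=O)=O)c(F)c1` is not yet measured. It differs from compound 1 as follows: pentylsulfanyl in place of butyl(methyl)amino on an aromatic carbon. The steps from compound 1 to compound 2 and from compound 1 to compound 3 bear on this change, since each exchanges the butyl(methyl)amino group at the same position for another group of similar size, and each stayed within the scatter. On that basis no step beyond the scatter is expected for compound 4 in this assay: the expected step is a 1.2-fold lower number from compound 1 to compound 4 (0.08 log units; within the scatter). For compound 4 the estimated value in this assay is 1 nM, with a range from 0.4 nM to 2.5 nM.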

Compound 4, inhibition constant: 3.1 nM
Estimate against measurement, compound 4: 3.1-fold (0.49 log units) below, and the stated range ends below it.
By their numbers in this assay, from the lowest: compounds 3, 2 and 1 (each within the scatter of the next); then compound 4.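

In this assay the group next to the ring nitrogen is not freely exchangeable: pentylsulfanyl, which matches butyl(methyl)amino in heavy atoms and hydrogen-bond acceptors, gives a 2.6-fold higher number from compound 1 to compound 4 (0.41 log units; beyond the scatter) in this comparison. Against the other two groups the exchange gives a 3.9-fold higher number from compound 3 to compound 4 (0.59 log units; beyond the scatter) and a 3.4-fold higher number from compound 2 to compound 4 (0.54 log units; beyond the scatter), so the thioether alone separates from the amines and the ether, by modest steps beyond the scatter. Nothing shown accounts for this separation.

Open, from the compounds shown here alone, is whether the step follows the sulfur or the particular chain: the thioether carries an unbranched pentyl chain and the ether a branched isopentyl one, so pentyloxy and isopentylsulfanyl on the shared core would separate the two. Also open, going by these compounds, is how a shorter thioether such as ethylsulfanyl, or the corresponding pentylsulfonyl group, would compare.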